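Three amides on a shared core, and a fourth to come

This account rests on a few compounds, and the source may have more. Where it says the series, first, only, none or still open, it means among the compounds named here.

Compound 1 `O=C(Nc1cccc(-c2oc3cc(-c4ccc(F)cc4)ccc3c(=O)c2O)c1)c1ccc(F)cc1`: 5350 nM
Compound 2 `O=C(Nc1cccc(-c2oc3cc(-c4ccc(F)cc4)ccc3c(=O)c2O)c1)c1ccc(Cl)cc1`: 3670 nM
Compound 3 `O=C(Nc1cccc(-c2oc3cc(-c4ccc(F)cc4)ccc3c(=O)c2O)c1)c1ccc(C(F)(F)F)cc1`: 17400 nM

Of the compounds shown here, three built on the same core have been measured in a functional assay on HeLa cells (Homo sapiens) for antiproliferative activity, read by CCK-8 assay, with a stated time of 72 h; on this read-out higher numbers stand for weaker inhibition and lower numbers for stronger inhibition. Compound 1 gives 5350 nM in this assay, which places it second highest of the three numbers. Its nearest neighbour is compound 2, and the change a 1.5-fold lower number from compound 1 to compound 2 (0.16 log units; within the scatter) lies within the scatter. Compound 3 stands furthest away, with a 3.3-fold higher number from compound 1 to compound 3 (0.51 log units; beyond the scatter); in the same direction, a 4.7-fold higher number from compound 2 to compound 3 (0.68 log units; beyond the scatter).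

Compound 4 `Cc1cccc(C(=O)Nc2cccc(-c3oc4cc(-c5ccc(F)cc5)ccc4c(=O)c3O)c2)c1` has not yet been measured. It differs from compound 1 in one place: 3-methylphenyl in place of 4-fluorophenyl on a carbonyl carbon. Among the compounds with values here, none of the measured steps carries this exact change, since all three measured compounds vary only the group on an aromatic carbon of the (4-fluorophenyl)carbonyl unit. What they do show is that fluoro and chloro give numbers within the scatter of each other, while trifluoromethyl gives a modestly higher number. A methyl on the entering 3-methylphenyl is a small group, more like fluoro or chloro than trifluoromethyl in size, so compound 4 is expected to stay within the scatter of compound 1, with a 1.1-fold lower number from compound 1 to compound 4 (0.03 log units; within the scatter) and no step in either direction beyond it. Compound 4 is therefore estimated at 5000 nM, with a range from 2000 nM to 14000 nM.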

Compound 4, half-maximal inhibitory concentration: 6650 nM
For compound 4 the middle estimate is 1.3-fold (0.12 log units) below the measured one; measured number inside the range.
By their numbers in this assay, from the lowest: compounds 2, 1 and 4 (each within the scatter of the next); then compound 3.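

In this assay, 3-methylphenyl in place of 4-fluorophenyl on a carbonyl carbon whose other neighbour is the amide-type nitrogen gives a 1.2-fold higher number from compound 1 to compound 4 (0.09 log units; within the scatter), and 3-methylphenyl in place of 4-chlorophenyl gives a 1.8-fold higher number from compound 2 to compound 4 (0.26 log units; within the scatter). The earlier compounds shown here all carried a halogen-bearing 4-substituted phenyl group here, so these steps add that a group of carbon only, with its substituent named at a different ring number, can stand in this place with no change beyond the scatter. Compound 3 remains the one apart among the four, as 3-methylphenyl in place of 4-(trifluoromethyl)phenyl gives a 2.6-fold lower number from compound 3 to compound 4 (0.42 log units; beyond the scatter), so the higher number is confined to that single group and does not extend to every change at this carbonyl carbon.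

Nothing shown here explains these numbers. From the compounds shown here alone, since the methyl and its ring number change together in compound 4, the effect of each alone stays open, as does the outcome with 4-methylphenyl, unsubstituted phenyl, or a ring carrying an amine, a carboxylic acid or a longer chain.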